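A few compounds are considered here, and "the series" means these few. Any claim that something is new, unique, unknown or untested is made for them only; others in the source may bear on it.

In a functional assay on HCT-116 cells (Homo sapiens) for antiproliferative activity, read by MTT assay, with a stated time of 48 h (a lower number here means a stronger inhibitor, a higher number a weaker inhibitor), compound 1 `CCCCCCC(CCO)n1cnc2c(Cl)ncnc21` gives 11900 nM. Compound 3 `CCCCCCCC(CCO)n1cnc2c(Cl)ncnc21` has a core that differs from that of compound 1 by methyl in place of hydrogen on a saturated chain carbon, seven bonds along the chain from an aromatic nitrogen; in this assay compound 3 gives 4160 nM, which is a 2.9-fold lower number from compound 1 to compound 3 (0.46 log units; beyond the scatter). Compound 2 `CCCCCCC(CCO)n1cnc2c(OC)ncnc21` carries methoxy in place of chloro on an aromatic carbon. For compound 2 the assay reports only a limit, > 50000 nM, namely (the limit of > 50000 nM in this assay, at which 1 of the 3 values shown sits). That is an at least 4.2-fold higher number from compound 1 to compound 2 (0.62 log units; beyond the scatter). Compound 4 `CCCCCCCC(CCO)n1cnc2c(OC)ncnc21`, not yet measured, carries the same change on the core of compound 3, (methoxy in place of chloro on an aromatic carbon), with the surroundings of the changed atom described in identical words for both pairs. The step from compound 3 to compound 4 is expected to be a 6.0-fold higher number from compound 3 to compound 4 (0.78 log units; beyond the scatter), resting on the earlier step of an at least 4.2-fold higher number from compound 1 to compound 2 (0.62 log units; beyond the scatter), which itself may be understated since compound 2 reached only a limit. Compound 4 is therefore estimated at 25000 nM, between 12000 nM and 60000 nM.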

Compound 4, half-maximal inhibitory concentration: 15300 nM
For compound 4 the middle estimate is 1.6-fold (0.21 log units) above the measured one; measured number inside the range.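

In this assay, methoxy in place of chloro raises the number on the core of compound 3 as well, with a 3.7-fold higher number from compound 3 to compound 4 (0.57 log units; beyond the scatter), so the direction of this change carries over from one core to the other: the same change on two cores in this assay, an at least 4.2-fold higher number (0.62 log units; beyond the scatter) from compound 1 to compound 2 and a 3.7-fold higher number (0.57 log units; beyond the scatter) from compound 3 to compound 4; the limit leaves it open whether they differ. Methyl in place of hydrogen on the chain lowers the number in the methoxy pair too, with an at least 3.2-fold lower number from compound 2 to compound 4 (0.51 log units; beyond the scatter), matching its direction in the chloro pair: the same change on two cores in this assay, a 2.9-fold lower number (0.46 log units; beyond the scatter) from compound 1 to compound 3 and an at least 3.2-fold lower number (0.51 log units; beyond the scatter) from compound 2 to compound 4; the limit leaves it open whether they differ. The value of compound 2 is only a limit, > 50000 nM, and these pairs show the direction of each change but not that its size is the same on both cores.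

The compounds shown leave open how an amine on this aromatic carbon would compare with chloro or methoxy. They also leave open whether a longer chain would lower the number further.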